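This account rests on a few compounds, and the source may have more. Where it says the series, first, only, none or still open, it means among the compounds named here.

Measured in a functional assay on HCT-15 cells (Homo sapiens); on this read-out lower numbers stand for an effect already at smaller amounts and higher numbers for an effect only at larger amounts of compound:
- Compound 1 `COc1cc(OC)c(C2OC(c3ccc(N)c(C)c3)=NN2C(C)=O)cc1OC`: 198 uM
- Compound 2 `COc1cc(C2OC(c3ccc(N(C)C)cc3)=NN2C(=O)COC(C)=O)cc(OC)c1OC`: 0.019 uM

Compound 2 has the lower number of the two, at 0.019 uM, and compound 1 stands at 198 uM. The gap between these two numbers lies far beyond the usual scatter. Compound 3 `COc1cc(C2OC(c3ccc(N(C)C)cc3)=NN2C(=O)CNC=O)cc(OC)c1OC` differs from compound 2 in one place: formylamino in place of acetoxy on a saturated chain carbon bound to a carbonyl carbon. This puts formylamino in place of acetoxy on a saturated chain carbon bound to a carbonyl carbon. Going by the values given here, no measured pair shows the effect of this change, so any forecast is uncertain. A moderate rise in this assay is expected, an estimated 4.2-fold higher number from compound 2 to compound 3 (0.62 log units; beyond the scatter). For compound 3, the estimated value is 0.08 uM, with an expected range of 0.01 uM to 1 uM.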

Compound 3, concentration for half-maximal effect: 0.035 uM
Compound 3: middle estimate off by 2.3-fold (0.36 log units), on the high side; measured number inside the range.
By their numbers in this assay, from the lowest: compounds 2 and 3 (each within the scatter of the next); then compound 1.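

In this assay, placing formylamino instead of acetoxy on this saturated chain carbon bound to a carbonyl carbon gives a 1.8-fold higher number from compound 2 to compound 3 (0.27 log units; within the scatter) and so no real difference. The position therefore accepts a group carrying a hydrogen-bond donor as well as one carrying none, without leaving the scatter. No available measurement explains this result.

As far as these compounds go, whether a free amine, a carboxylic acid or a longer chain on this carbon would also stay within the scatter remains open.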